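Thiadiazole for Oxadiazole: A Step Expected Within Scatter

The source may report more compounds than this note shows. Statements on the series, on what has been measured and on what is new or still open speak of the compounds shown alone.

Compound 1, `COc1cnc(N2CCC(CCCNc3ccc4c(c3)OCC4=O)CC2)nc1`, in a functional assay on CHO-K1 cells for agonist activity at Glucose-dependent insulinotropic receptor (Homo sapiens), read by HTRF and cAMP accumulation, with a stated time of 30 min; a lower number here means a smaller maximal response, a higher number a larger maximal response: 101%
Compound 2, `COC(=O)c1cnc(N2CCC(CCCNc3ccc4c(c3)OCC4=O)CC2)nc1`, in this assay: 85%
Compound 3, `CC(C)c1nc(N2CCC(CCCNc3ccc4c(c3)OCC4=O)CC2)no1`, in this assay: 91%

Compound 3 differs from compound 1 by a number 10 percentage points lower from compound 1 to compound 3 (within the scatter) and from compound 2 by a number 6 percentage points higher from compound 2 to compound 3 (within the scatter); both steps are within the scatter, so compound 3 cannot be told apart from either on these numbers. Among the measured compounds shown here, the only step beyond the scatter so far is a number 16 percentage points lower from compound 1 to compound 2 (beyond the scatter), a change within the group on the amine nitrogen rather than an exchange of that whole group.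

Compound 4 is `CC(C)c1nsc(N2CCC(CCCNc3ccc4c(c3)OCC4=O)CC2)n1`. The change is 3-isopropyl-1,2,4-thiadiazol-5-yl in place of 5-isopropyl-1,2,4-oxadiazol-3-yl on an amine nitrogen in a ring. For the measured compounds named here, the steps that bear on it are the two exchanges of the whole group on that nitrogen, from compound 1 to compound 3 and from compound 2 to compound 3, and both stayed within the scatter. A step of similar kind is therefore expected to stay within the scatter in this assay, with no clear direction.

Compound 4 is thus expected to give 91%, in the range 78% to 104%. The step this estimate means, no change at the digits printed from compound 3 to compound 4 (within the scatter), is expected to lie within the scatter.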

Compound 4, largest response reached (Emax), in percent of the reference or control that the assay uses: 10%
Compound 4: the middle estimate sits 81 percentage points above what was measured; measured number below the stated range.
By their numbers in this assay, from the lowest: compound 4; then compounds 2, 3 and 1 (each within the scatter of the next, the first and the last beyond it).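

In this assay, among the compounds shown here, the group on the amine nitrogen in a ring proved far less forgiving than the earlier compounds suggested, with a number 81 percentage points lower from compound 3 to compound 4 (beyond the scatter) even though both groups carry an isopropyl and match in heavy atoms and hydrogen-bond counts. The names show two differences: sulfur stands in place of oxygen, and the ring is attached through a different ring position. The gap also holds against the two pyrimidine compounds, with a number 75 percentage points lower from compound 2 to compound 4 (beyond the scatter) and a number 91 percentage points lower from compound 1 to compound 4 (beyond the scatter), so among these four the low response belongs to the 3-isopropyl-1,2,4-thiadiazol-5-yl group alone, and nothing available explains it.

As far as these compounds go, whether the loss follows the sulfur or the changed attachment stays open, as the two come together in compound 4. Also open, from the compounds shown here alone, is how this assay would respond to this thiadiazole ring carrying an amine or a longer chain in place of the isopropyl.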